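From compound 2 to compound 4: methoxy for methyl

This account rests on a few compounds, and the source may have more. Where it says the series, first, only, none or still open, it means among the compounds named here.

Measured so far in a functional assay on the whole organism for antagonist activity, with Mus musculus as the target, in the maximal electroshock model (on this read-out lower numbers stand for an effect already at smaller amounts and higher numbers for an effect only at larger amounts of compound), as limits, not numbers:
compound 1 `Cn1c(-c2ccccc2)nnc1[S+](C)[O-]` gives > 100 mg/kg as a limit
compound 2 `Cc1ccc(-c2nnc([S+](C)[O-])n2C)cc1` gives > 200 mg/kg as a limit
compound 3 `Cc1ccc(-c2nnc(S(C)(=O)=O)n2C)cc1` gives > 200 mg/kg as a limit

Compound 2 stands only at the limit > 200 mg/kg and no number is known for it. The change to compound 4 `COc1ccc(-c2nnc([S+](C)[O-])n2C)cc1` is methoxy in place of methyl on an aromatic carbon, with methoxy in place of methyl on an aromatic carbon as the count. Among the compounds with values here, two measured steps bear on it, a step that the two limits leave unreadable from compound 1 to compound 2 on an aromatic carbon and a step that the two limits leave unreadable from compound 2 to compound 3 at another place. As far as these compounds go, neither gives a size that can be carried over, and the direction stays open. In this assay a limit is again the expected outcome for compound 4. The estimated step that the limit leaves unreadable from compound 2 to compound 4 is a placeholder with no direction behind it. For compound 4 the estimated value is 220 mg/kg with an expected range from 70 mg/kg to 600 mg/kg as its spread.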

Compound 4, dose for half-maximal effect: > 100 mg/kg
Compound 4: a limit, no number (the forecaster's own chance of this, stated with the estimate: 65%); the middle value is on the limit's open side.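

In this assay, compound 4 gives the limit > 100 mg/kg, and neither its step from compound 2 nor its step from compound 1 can be read. The compounds shown leave open whether hydrogen, methyl or methoxy on the aromatic carbon makes any difference to the dose for half-maximal effect.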